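Halogen swap at the fused core: cytotoxicity notes

A few compounds are considered here, and "the series" means these few. Any claim that something is new, unique, unknown or untested is made for them only; others in the source may bear on it.

Three compounds share a core and are measured in a functional assay on V79 cells (Cricetulus griseus) for cytotoxicity, read by colony formation; on this read-out higher numbers stand for weaker inhibition and lower numbers for stronger inhibition. Compound 1 `NCC1CCN(c2c(F)cc3c(=O)c(C(=O)O)cn(C4CC4)c3c2F)C1` gives 11 ug/mL. Compound 2 `NCC1CCN(c2c(F)cc3c(=O)c(C(=O)O)cn(C4CC4)c3c2Cl)C1` gives 8 ug/mL. Compound 3 `CNCC1(C)CCN(c2c(F)cc3c(=O)c(C(=O)O)cn(C4CC4)c3c2F)C1` gives 8 ug/mL. The cores of compound 1 and compound 3 differ by 3-methyl-3-((methylamino)methyl)pyrrolidin-1-yl in place of 3-(aminomethyl)pyrrolidin-1-yl on an aromatic carbon. The step of a 1.4-fold lower number from compound 1 to compound 3 (0.14 log units; within the scatter) is small. The halogen swap chloro in place of fluoro on an aromatic carbon gives the step of a 1.4-fold lower number from compound 1 to compound 2 (0.14 log units; within the scatter), so in this assay the swap barely moves the number.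

Compound 4 `CNCC1(C)CCN(c2c(F)cc3c(=O)c(C(=O)O)cn(C4CC4)c3c2Cl)C1` is not yet measured. It differs from compound 3 by chloro in place of fluoro on an aromatic carbon. The surroundings of the place are not identical to those of the swap in compound 1: in compound 4 the place is ortho to a 3-methyl-3-((methylamino)methyl)pyrrolidin-1-yl group (9 heavy atoms), whereas in compound 2 it is ortho to a 3-(aminomethyl)pyrrolidin-1-yl group (7 heavy atoms); it is the same kind of change, not the same change. For compound 4 the expected step is a 1.3-fold lower number from compound 3 to compound 4 (0.12 log units; within the scatter), set beside a 1.4-fold lower number from compound 1 to compound 2 (0.14 log units; within the scatter), because compound 3 gives 8 ug/mL and the earlier swap stayed within the scatter. Compound 4 is therefore estimated at 6 ug/mL, with an expected range from 3 ug/mL to 13 ug/mL.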

Compound 4, half-maximal inhibitory concentration: 23 ug/mL
Beside the measured number, compound 4's estimate is 3.8-fold (0.58 log units) below it, outside the stated range (above it).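

In this assay, chloro in place of fluoro in the presence of the 3-methyl-3-((methylamino)methyl)pyrrolidin-1-yl group gives a 2.9-fold higher number from compound 3 to compound 4 (0.46 log units; beyond the scatter), and this does not match the same swap in the presence of the 3-(aminomethyl)pyrrolidin-1-yl group: the same change on two cores in this assay, a 1.4-fold lower number (0.14 log units; within the scatter) from compound 1 to compound 2 and a 2.9-fold higher number (0.46 log units; beyond the scatter) from compound 3 to compound 4, 4.0-fold (0.60 log units) apart, beyond the scatter of two such steps

Read the other way, the exchange of pyrrolidinyl groups with chloro on the core gives a 2.9-fold higher number from compound 2 to compound 4 (0.46 log units; beyond the scatter), and this does not match the same exchange with fluoro on the core: the same change on two cores in this assay, a 1.4-fold lower number (0.14 log units; within the scatter) from compound 1 to compound 3 and a 2.9-fold higher number (0.46 log units; beyond the scatter) from compound 2 to compound 4, 4.0-fold (0.60 log units) apart, beyond the scatter of two such steps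

The halogen swap therefore does not carry unchanged from one core to the other here, but these two comparisons rest on the same four compounds, so they form a single observation and show neither a general rule for the series nor a reason for the difference.

The compounds shown leave open whether the ring methyl or the methyl on the amine goes with the higher number for compound 4. Going by these compounds, it also remains open how a bromo group or a methoxy group at the halogen's place would behave with either pyrrolidinyl group.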